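Replacing the silicon group of compound 1

The compounds below may be only part of what the source reports. "The series", "measured", "known", "first", "only" and "open" are said of these compounds alone.

- compound 1 `C[Si](C)(C)Cn1nnc2c(C(N)=O)ncn2c1=O` reads 28400 nM
- compound 2 `COc1ccc(Cn2nnc3c(C(N)=O)ncn3c2=O)cc1` reads > 50000 nM as a limit
- compound 3 `COc1ccc(Cn2nnc3c(C(N)=O)ncn3c2=O)c(OC)c1` reads > 50000 nM as a limit

Among the compounds with values here, in a functional assay on SNB-19 cells (Homo sapiens) for inhibition, read by MTT assay, with a stated time of 7 days (on this read-out lower numbers stand for stronger inhibition of growth and higher numbers for weaker inhibition of growth), compound 1 gives 28400 nM as the only number. The other two values are limits (the limit of > 50000 nM in this assay, at which 2 of the 3 values shown sit). Compound 4 `NC(=O)c1ncn2c(=O)n(Cc3c[nH]nn3)nnc12` is unmeasured and differs from compound 1 as follows (a group of 5 heavy atoms (2 carbon, 3 nitrogen; one five-membered aromatic ring with 3 hetero atoms) in place of a group of 4 heavy atoms (3 carbon, 1 silicon; no ring), on a saturated chain carbon bound to an aromatic nitrogen). Within the data shown here, the one measured step (a step that the two limits leave unreadable from compound 2 to compound 3) gives no size to carry over. Compound 2 also has an aromatic ring on that chain carbon and reads > 50000 nM as a limit, which is the ground for expecting weaker inhibition of growth in compound 4. The expected step is modest (a 2.5-fold higher number from compound 1 to compound 4 (0.39 log units; beyond the scatter)). Compound 4 is estimated at 70000 nM with a range from 25000 nM to 200000 nM. It is expected that compound 4 may also end up as a limit rather than a number.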

Compound 4, concentration for 50% growth inhibition: > 50000 nM
Compound 4 was reported as a limit; the forecaster's own chance of this, stated with the estimate: 60%; the middle value lies beyond the limit too.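

In this assay compound 4 reads > 50000 nM, which is a limit and not a number. Placing 1H-1,2,3-triazol-4-yl on the saturated chain carbon bound to an aromatic nitrogen gives an at least 1.7-fold higher number from compound 1 to compound 4 (0.24 log units; that floor lies within the scatter), so the floor of this step does not separate the two compounds. The same limit is now shared by compound 2, compound 3 and compound 4: the limit of > 50000 nM in this assay, at which 3 of the 4 values shown sit.

The true size of this step cannot be read, nor can the step between the two methoxy compounds. From the compounds shown here alone, whether an amine, a carboxylic acid or a longer alkyl chain on that carbon would give a number remains open.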